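Removing the ortho methyl: compound 2 to compound 3

The source may report more compounds than this note shows. Statements on the series, on what has been measured and on what is new or still open speak of the compounds shown alone.

Of the compounds shown here, two in this set have been measured. Compound 1 `Cn1c(-c2ccc(O)cc2)nc2c(NC3CCCC3)ncnc21` gives 17 nM in an assay on CHO cells for displacement of a labelled ligand from adenosine receptor A1 (Homo sapiens), read by scintillation counting, with a stated time of 3 h (on this read-out higher numbers stand for weaker inhibition and lower numbers for stronger inhibition), and compound 2 `Cc1ccccc1-c1nc2c(NC3CCCC3)ncnc2n1C` gives 55 nM in this assay. Compound 2 therefore stands with the higher of the two numbers: the step of a 3.2-fold higher number from compound 1 to compound 2 (0.51 log units; beyond the scatter) came with 2-methylphenyl in place of 4-hydroxyphenyl on an aromatic carbon. Compound 3 `Cn1c(-c2ccccc2)nc2c(NC3CCCC3)ncnc21` is not yet measured. It differs from compound 2 by hydrogen in place of methyl on an aromatic carbon, which, cut one bond further out, reads 2-methylphenyl to phenyl. Going by the values given here, no measured step bears directly on this change; the only step on record exchanges the whole aryl group rather than a single methyl. Compound 3 is expected to lie close to compound 2, with the step of a 1.4-fold lower number from compound 2 to compound 3 (0.14 log units; within the scatter) expected to be within the scatter or slightly toward lower numbers. The estimate for compound 3 in this assay is 40 nM, with a range from 15 nM to 120 nM.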

Compound 3, inhibition constant: 2.8 nM
The estimate for compound 3 lay 14-fold (1.15 log units) above the measured number, and the stated range ends above it.
By their numbers in this assay, from the lowest: compound 3; then compound 1; then compound 2.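

In this assay the loss of one methyl, ortho to a large group, brought a 20-fold lower number from compound 2 to compound 3 (1.29 log units; beyond the scatter), so a single heavy atom at this place on the aromatic ring counts for far more than the earlier exchange of whole aryl groups could show. With a 6.1-fold lower number from compound 1 to compound 3 (0.78 log units; beyond the scatter) for hydrogen in place of hydroxy, plain phenyl gives the lowest number of the three compounds, and both the 2-methylphenyl and the 4-hydroxyphenyl compounds stand above it. No evidence here speaks to what lies behind the size of these steps.

The compounds shown leave open whether fluorine or a methoxy group at the place of the methyl would give a similarly higher number. They also leave open whether a methyl elsewhere on the phenyl ring would do the same.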